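Replacing 4-hydroxyphenyl with 3-bromophenyl in compound 2

The compounds below may be only part of what the source reports. "The series", "measured", "known", "first", "only" and "open" are said of these compounds alone.

Compound 1 `O=C(/C=C/c1cccc(OCc2ccccc2)c1)c1ccc(Cl)cc1Cl` gives 9400 nM
Compound 2 `O=C(/C=C/c1cccc(OCc2ccccc2)c1)c1ccc(O)cc1` gives 2800 nM
Compound 3 `Cc1ccc(C(=O)/C=C/c2cccc(OCc3ccccc3)c2)cc1` gives 21700 nM

These values come from a functional assay on MCF7 cells (Homo sapiens) for cytotoxicity, read by MTT assay, with a stated time of 68 h (on this read-out lower numbers stand for stronger inhibition and higher numbers for weaker inhibition), and compound 2 has the lowest of the three. Compound 4 `O=C(/C=C/c1cccc(OCc2ccccc2)c1)c1cccc(Br)c1` is still unmeasured. Compared with compound 2, it has 3-bromophenyl in place of 4-hydroxyphenyl on a carbonyl carbon. Within the data shown here, two measured steps bear on this change: 4-hydroxyphenyl in place of 2,4-dichlorophenyl gave a 3.4-fold lower number from compound 1 to compound 2 (0.53 log units; beyond the scatter) and methyl in place of hydroxy gave a 7.8-fold higher number from compound 2 to compound 3 (0.89 log units; beyond the scatter) in the same test. In both, the compound without the hydroxy group has the higher number. Among the measured compounds shown here, no bromine-bearing compound has been measured. A higher number is therefore expected, an estimated 3.6-fold higher number from compound 2 to compound 4 (0.55 log units; beyond the scatter) in this assay and similar in size to those steps. For compound 4 the expected value is 10000 nM with an estimated range of 3500 nM to 28000 nM for this measurement.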

Compound 4, half-maximal inhibitory concentration: 7900 nM
For compound 4 the middle estimate is 1.3-fold (0.10 log units) above the measured one, and the stated range covers the measured number.
By their numbers in this assay, from the lowest: compound 2; then compounds 4 and 1 (each within the scatter of the next); then compound 3.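

With 3-bromophenyl in place of 4-hydroxyphenyl on the carbonyl carbon, this assay shows a 2.8-fold higher number from compound 2 to compound 4 (0.45 log units; beyond the scatter), so all three compounds without a hydroxy group now have higher numbers than compound 2. The rings without a hydroxy group also differ among themselves: 3-bromophenyl in place of 4-methylphenyl gives a 2.7-fold lower number from compound 3 to compound 4 (0.44 log units; beyond the scatter), while 3-bromophenyl in place of 2,4-dichlorophenyl gives only a 1.2-fold lower number from compound 1 to compound 4 (0.08 log units; within the scatter). Still open, on these data alone, is whether the hydroxy group itself matters or its place on the ring, and whether an amine or a carboxylic acid there would match compound 2. Nothing measured here gives a reason for these differences.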